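The source may report more compounds than this note shows. Statements on the series, on what has been measured and on what is new or still open speak of the compounds shown alone.

Measured so far in a functional assay on PC-3 cells (Homo sapiens) for cytotoxicity; on this read-out lower numbers stand for stronger inhibition and higher numbers for weaker inhibition:
- compound 3 `O=C(N/N=C\c1cn(Cc2ccc(Cl)cc2)c2ccc(Br)cc12)c1c[nH]c2ccccc12` gives 12400 nM
- compound 2 `O=C(N/N=C\c1cn(Cc2ccc(Cl)cc2)c2cc(F)ccc12)c1c[nH]c2ccccc12` gives 19500 nM
- compound 1 `COc1ccc2c(c1)c(/C=N\NC(=O)c1c[nH]c3ccccc13)cn2Cc1ccc(Cl)cc1` gives 30300 nM

Compound 3 has the lowest of the three numbers, though its gap to compound 2 lies within the usual scatter; only compound 1 sits clearly apart from it. Compound 4 `O=C(N/N=C\c1cn(Cc2ccc(Cl)cc2)c2ccccc12)c1c[nH]c2ccccc12` differs from compound 3 by hydrogen in place of bromo on an aromatic carbon. Among the compounds with values here, no measured step removes a group from this position altogether, so only the swap a 2.4-fold lower number from compound 1 to compound 3 (0.39 log units; beyond the scatter) bears on it, and it shows that changing the group at this position moves the read-out modestly. Removing the bromo is therefore expected to weaken inhibition a little, and the expected step is a 1.6-fold higher number from compound 3 to compound 4 (0.21 log units; within the scatter). Compound 4 is estimated to give 20000 nM, with a range from 8000 nM to 50000 nM.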

Compound 4, half-maximal inhibitory concentration: 16200 nM
Estimate against measurement, compound 4: 1.2-fold (0.09 log units) above; measured number inside the range.
By their numbers in this assay, from the lowest: compounds 3, 4, 2 and 1 (each within the scatter of the next, the first and the last beyond it).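

Hydrogen on this aromatic carbon gives the shared core a plain reference point in this assay. Removing each group leaves the number within the scatter: bromo (a 1.3-fold higher number from compound 3 to compound 4 (0.12 log units; within the scatter)), fluoro (a 1.2-fold lower number from compound 2 to compound 4 (0.08 log units; within the scatter)) and methoxy (a 1.9-fold lower number from compound 1 to compound 4 (0.27 log units; within the scatter)). So none of these three groups can be told apart from hydrogen, even though compound 1 and compound 3 differ clearly. No measurement shown accounts for these small steps. From the compounds shown here alone, whether an amine or a carboxylic acid here would move the number beyond the scatter stays open.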